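This account rests on a few compounds, and the source may have more. Where it says the series, first, only, none or still open, it means among the compounds named here.

Compound 1 `CCCCCSc1nc(OC(=O)CC(C)(C)C)c2cn[nH]c2n1` gives 18900 nM
Compound 2 `CCCCCSc1nc(Nc2ccccc2Cl)c2cn[nH]c2n1` gives 19200 nM
Compound 3 `O=[N+]([O-])c1cccc(Nc2nc(SCCc3ccccc3)nc3[nH]ncc23)c1` gives 19200 nM

In a functional assay on MCF7 cells (Homo sapiens) for antiproliferative activity, read by fluorescence, with a stated time of 3 days (on this read-out lower numbers stand for stronger inhibition and higher numbers for weaker inhibition), compound 1 reads 18900 nM and stands level with compound 2 and compound 3, since all three numbers lie within the usual scatter of one another. Compound 4 `CCCCCSc1nc(OC(=O)c2ccccc2)c2cn[nH]c2n1` keeps the core of compound 1 and changes one group: phenyl in place of neopentyl on a carbonyl carbon. Going by the values given here, no measured pair shows this change or any other single change, so the data offer no direct guide. Compound 1 at 18900 nM and compound 3 at 19200 nM carry quite different groups yet sit within the scatter, so no step beyond the scatter is expected, in either direction. The expected change is a 1.2-fold lower number from compound 1 to compound 4 (0.07 log units; within the scatter). For compound 4 the estimated value is 16000 nM, with an expected range of 7000 nM to 40000 nM.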

Compound 4, half-maximal inhibitory concentration: 18900 nM
Compound 4: middle estimate off by 1.2-fold (0.07 log units), on the low side; measured number inside the range.
By their numbers in this assay, from the lowest: compounds 1, 4, 2 and 3 (each within the scatter of the next).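

In this assay phenyl in place of neopentyl on a carbonyl carbon gives no change at the digits printed from compound 1 to compound 4 (within the scatter) at this position. The earlier compounds shown here differ in more than one place, whereas this pair isolates a single change, and it shows that an open branched group and an aromatic ring can stand here with no step beyond the scatter. Nothing at hand explains why the two groups read alike. Still open, on these data alone, is whether an amine, a carboxylic acid or a longer chain on this carbonyl carbon would move the number.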